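The compounds below may be only part of what the source reports. "The series", "measured", "known", "first", "only" and "open" are said of these compounds alone.

Working notes on the series. Three compounds share a core and differ at one aromatic carbon: compound 1 `c1cncc(-c2cncc(N3CCCNCC3)c2)c1`, compound 2 `NC(=O)c1cncc(N2CCCNCC2)c1` and compound 3 `Oc1cncc(N2CCCNCC2)c1`. In an assay on cell membranes for binding affinity to Neuronal acetylcholine receptor; alpha4/beta2 (Rattus norvegicus), read by radioligand binding (a higher number here means a weaker inhibitor, a lower number a stronger inhibitor), compound 1 gives 2.8 nM, compound 2 gives 20 nM and compound 3 gives 2.4 nM. Compound 3 holds the lowest of the three numbers; the step of a 1.2-fold lower number from compound 1 to compound 3 (0.07 log units; within the scatter) stays within the scatter, while the step of an 8.3-fold lower number from compound 2 to compound 3 (0.92 log units; beyond the scatter) and the step of a 7.1-fold higher number from compound 1 to compound 2 (0.85 log units; beyond the scatter) set compound 2 apart from both.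

The next compound, compound 4 `OCCOc1cncc(N2CCCNCC2)c1`, is not yet measured. It differs from compound 3 by 2-hydroxyethyl in place of hydrogen on an oxygen on an aromatic ring. Going by the values given here, none of the measured steps alters the hydroxy group itself; the steps that bear on this position all swap the whole substituent. What they show is that the position tolerates a large group without loss of potency, as the step from compound 1 to compound 3 is within the scatter, whereas carbamoyl costs a modest amount. Capping the hydroxy with a 2-hydroxyethyl chain is expected to cost little to a modest amount, so a step of a 2.5-fold higher number from compound 3 to compound 4 (0.40 log units; beyond the scatter) in this assay is estimated. Compound 4 is therefore expected near 6 nM, within a range of 1.5 nM to 25 nM.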

Compound 4, half-maximal inhibitory concentration: 1.8 nM
For compound 4 the middle estimate is 3.3-fold (0.52 log units) above the measured one, and the stated range covers the measured number.
By their numbers in this assay, from the lowest: compounds 4, 3 and 1 (each within the scatter of the next); then compound 2.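

In this assay, the hydroxy oxygen of compound 3 takes a 2-hydroxyethyl group with no readable change, a 1.3-fold lower number from compound 3 to compound 4 (0.12 log units; within the scatter). Going by these compounds alone, this is the first change made on the oxygen itself rather than by swapping the whole substituent, and it shows that the number holds when the hydrogen on that oxygen is replaced; the 2-hydroxyethoxy group also stands level with pyridin-3-yl, a 1.6-fold lower number from compound 1 to compound 4 (0.19 log units; within the scatter), while carbamoyl stays apart, an 11-fold lower number from compound 2 to compound 4 (1.05 log units; beyond the scatter), so among the four compounds carbamoyl is the only substituent that separates from the others. Nothing measured here speaks to why the oxygen accepts this chain.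

The compounds shown leave open whether a longer chain on this oxygen, a plain methyl ether, or a chain ending in an amine or a carboxylic acid would hold the number as the 2-hydroxyethyl group does. They also leave open whether the hydroxy of the chain contributes anything, for which an ethyl group on the same oxygen would give the direct comparison.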